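This account rests on a few compounds, and the source may have more. Where it says the series, first, only, none or still open, it means among the compounds named here.

Compound 1 `COc1ccc(C(=O)Nc2c(F)cccc2F)cc1OC1CCCC1` gives, in an assay on isolated protein for inhibition of phosphodiesterase 4A (Sus scrofa) (a lower number here means a stronger inhibitor, a higher number a weaker inhibitor), 70 nM, the lowest of the two numbers recorded so far, while compound 2 `COc1ccc(C(=O)Nc2c(F)cccc2F)cc1OC1CCCCC1` gives 400 nM in this assay. Among the measured compounds shown here, the only measured step, a 5.7-fold higher number from compound 1 to compound 2 (0.76 log units; beyond the scatter), concerns the ring on the oxygen and leaves the amide side of the molecule untouched. Compound 3 `COc1ccc(C(=O)Nc2ccccn2)cc1OC1CCCC1` keeps the cyclopentyl ether of compound 1 and differs from it only in pyridin-2-yl in place of 2,6-difluorophenyl on an amide-type nitrogen. No measured step bears on a change at the amide nitrogen, so the move from compound 1 to compound 3 has no direct precedent among these two compounds; the one known step sits elsewhere and is of modest size. In the absence of a guide, the number is expected to shift by about a 2.9-fold higher number from compound 1 to compound 3 (0.46 log units; beyond the scatter), more likely upward than downward. Compound 3 is therefore estimated at 200 nM in this assay, with a range from 40 nM to 1000 nM.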

Compound 3, half-maximal inhibitory concentration: 1000 nM
The estimate for compound 3 lay 5.0-fold (0.70 log units) below the measured number; low and high end bracket the measured number.
By their numbers in this assay, from the lowest: compound 1; then compound 2; then compound 3.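

In this assay, the amide-type nitrogen proves to be a place where the group carried matters: pyridin-2-yl in place of 2,6-difluorophenyl gives a 14-fold higher number from compound 1 to compound 3 (1.15 log units; beyond the scatter). Among the compounds shown here, the earlier compounds showed a change only on the oxygen, so this is the first sign that the amide side also moves the number, and of the two groups compared here, 2,6-difluorophenyl gives the lower number. Nothing available explains this step.

The compounds shown leave open whether the step follows from the ring nitrogen that enters or the two fluorine atoms that leave, a question that a plain phenyl on the amide-type nitrogen would address. They also leave open how a dichloropyridinyl group at this place would compare with 2,6-difluorophenyl.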